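This account rests on a few compounds, and the source may have more. Where it says the series, first, only, none or still open, it means among the compounds named here.

Measured compounds:
Compound 1 `COc1ccc(/C=C/C(=O)c2sc(Nc3ccc(Cl)cc3)nc2C)cc1` — in a functional assay on NCI-H460 cells (Homo sapiens) for cytotoxicity, read by MTT assay (on this read-out higher numbers stand for weaker inhibition and lower numbers for stronger inhibition), compound 1 gives > 25000 nM.
Compound 2 `Cc1nc(Nc2ccccc2)sc1C(=O)/C=C/c1ccc(Cl)cc1` — in this assay compound 2 gives > 25000 nM.

The value for compound 1 is only a limit of the assay, not a number. The value for compound 2 is likewise only a limit of the assay. Among the measured compounds shown here, compound 2 therefore stands at the limit itself, which is where both values shown sit (the limit of > 25000 nM in this assay, at which 2 of the 2 values shown sit), so no step between measured compounds can be read off. Compound 3 `Cc1nc(Nc2ccc(Cl)cc2)sc1C(=O)/C=C/c1ccc(Cl)cc1` differs from compound 2 by chloro in place of hydrogen on an aromatic carbon. For the measured compounds named here, with no measured step to lean on, the expected step of a number no higher from compound 2 to compound 3 (the limit leaves the size open) is none beyond the scatter, and compound 3 is expected most probably to return another limit in this assay. Compound 3 is estimated at 25000 nM, with a range from 8000 nM to 60000 nM.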

Compound 3, half-maximal inhibitory concentration: > 25000 nM
Compound 3: only a limit was reported; the forecaster's own chance of this, stated with the estimate: 75%; the middle value lies on the limit itself.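

In this assay compound 3 gives > 25000 nM, which is a limit and not a number. No step from compound 1 or compound 2 to compound 3 can be read: the limit of > 25000 nM in this assay, at which 3 of the 3 values shown sit.

The compounds shown leave open whether chloro in place of hydrogen or methoxy changes this read-out at all.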